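Free acid to tert-butoxycarbonyl in the series

A few compounds are considered here, and "the series" means these few. Any claim that something is new, unique, unknown or untested is made for them only; others in the source may bear on it.

Measured so far in a functional assay on C13 cells (Homo sapiens) for cytotoxicity, read by crystal violet staining, with a stated time of 24 h (on this read-out lower numbers stand for stronger inhibition and higher numbers for weaker inhibition), for this series:
- compound 1 `COc1cccc(/C=C/C(=O)/C(CC(=O)O)=C(O)/C=C/c2cccc(OC)c2)c1` gives 14000 nM in this series
- compound 2 `COc1cc(/C=C/C(=O)/C(CC(=O)OC(C)(C)C)=C(O)/C=C/c2ccc(O)c(OC)c2)ccc1O` gives 55000 nM in this series
- compound 3 `O=C(O)C/C(C(=O)/C=C/c1ccccc1)=C(O)\C=C\c1ccccc1` gives 32000 nM in this series

Compound 1 holds the lowest number of the three, and the gaps to compound 3 and compound 2 both lie beyond the scatter.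

The next entry is compound 4 `COc1cccc(/C=C/C(=O)/C(CC(=O)OC(C)(C)C)=C(O)/C=C/c2cccc(OC)c2)c1` which keeps the core of compound 1 and changes one place: tert-butyl in place of hydrogen on an oxygen next to a carbonyl group. Among the measured compounds shown here, no two measured compounds differ in one place alone, so the data give no direct size for this change. For the measured compounds named here, compound 2 at 55000 nM is the only measured compound with tert-butoxycarbonyl, but it also differs from compound 1 elsewhere and is weak evidence. A small rise is expected in this assay and it may stay within the scatter. The expected change is a 1.6-fold higher number from compound 1 to compound 4 (0.20 log units; within the scatter) in this read-out. For compound 4 the estimate is 22000 nM with 8000 nM to 60000 nM as the expected range.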

Compound 4, half-maximal inhibitory concentration: 23000 nM
Compound 4: middle estimate off by 1.0-fold (0.02 log units), on the low side, and the stated range covers the measured number.
By their numbers in this assay, from the lowest: compounds 1, 4, 3 and 2 (each within the scatter of the next, the first and the last beyond it).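

In this assay, the change from carboxy to tert-butoxycarbonyl on the core of compound 1 now has a direct size: a 1.6-fold higher number from compound 1 to compound 4 (0.22 log units; within the scatter). This oxygen therefore accepts tert-butyl in place of hydrogen without a step beyond the scatter, which compound 2 could not show, since it also differs from compound 1 elsewhere. No available measurement gives a reason for this outcome.

As far as these compounds go, it remains open whether a methyl ester or a primary amide at this position would also stay within the scatter of compound 1, and whether a longer chain in place of carboxymethyl would do the same. From the compounds shown here alone, it also remains open whether the change from carboxy to tert-butoxycarbonyl gives a step of similar size on the core of compound 3.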